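This account rests on a few compounds, and the source may have more. Where it says the series, first, only, none or still open, it means among the compounds named here.

Working notes on the series. Three compounds have been run in a functional assay on IGROV-1 cells (Homo sapiens) for cytotoxicity, read by sulforhodamine B assay, with a stated time of 48 h; on this read-out higher numbers stand for weaker inhibition of growth and lower numbers for stronger inhibition of growth. Compound 1 `ClCc1ccccc1Cn1cnc2c(Cl)nc(Cl)nc21` gives 1540 nM. Compound 2 `ClCc1ccccc1Cn1cnc2ncnc(Cl)c21` gives 4260 nM, the highest number of the three. Compound 3 `Nc1nc(Cl)c2ncn(Cc3cccc(CCl)c3)c2n1` gives 3460 nM; compound 2 and compound 3 lie within the usual scatter of each other, so no order is read from them. Compound 1 stands apart from compound 2 by a gap beyond the scatter, the number of compound 1 being the lower one. No pair among these three differs in a single place, so no clean step is available.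

The next compound, compound 4 `ClCc1ccccc1Cn1cnc2nc(Cl)nc(Cl)c21`, comes from compound 2 by a single change: chloro in place of hydrogen on an aromatic carbon. Within the data shown here, no measured step of this kind exists here. The expectation is a move to a lower number in this assay, of a moderate size, resting on the value of compound 1, because compound 1 carries two chloro groups on its core and gives 1540 nM. The step from compound 2 to compound 4 is thus estimated as a 1.9-fold lower number from compound 2 to compound 4 (0.29 log units; within the scatter). For compound 4 the estimate is 2200 nM, with a range from 1000 nM to 5000 nM.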

Compound 4, concentration for 50% growth inhibition: 2880 nM
Beside the measured number, compound 4's estimate is 1.3-fold (0.12 log units) below it, and the stated range covers the measured number.
By their numbers in this assay, from the lowest: compounds 1, 4, 3 and 2 (each within the scatter of the next, the first and the last beyond it).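

Among these compounds, this is the first single-place step: chloro in place of hydrogen on an aromatic carbon, between two ring nitrogen atoms, gives a 1.5-fold lower number from compound 2 to compound 4 (0.17 log units; within the scatter) in this assay. The position therefore takes a chloro group with no step beyond the scatter, so on this read-out the change leaves growth inhibition not distinguishable from that of the parent compound. Nothing available here bears on why the step has this size.

From the compounds shown here alone, whether a methoxy group or a carboxylic acid on this same carbon would give a step beyond the scatter remains open. Also open, going by these compounds, is whether chloro at this position gives a similar step in other cell lines or on compounds that differ elsewhere on the shared core.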